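From a fluorophenyl to an ethoxyphenyl amine

The source may report more compounds than this note shows. Statements on the series, on what has been measured and on what is new or still open speak of the compounds shown alone.

In a functional assay on HeLa cells (Homo sapiens) for inhibition, read by sulforhodamine B assay (on this read-out lower numbers stand for stronger inhibition and higher numbers for weaker inhibition), compound 3 `O=C1C=C(Nc2cccc(F)c2)C(=O)c2c1nc1n2[C@H]2OC[C@@H](O)[C@H]2OC1` gives 6440 nM and compound 2 `O=C1C=C(Nc2ccccc2F)C(=O)c2c1nc1n2[C@H]2OC[C@@H](O)[C@H]2OC1` gives 5120 nM, two values within the scatter of each other. Compound 1 `O=C1C=C(N2CCC2)C(=O)c2c1nc1n2[C@H]2OC[C@@H](O)[C@H]2OC1` reads > 16000 nM, which is a limit of the assay and not a number. Compound 4 `CCOc1ccc(NC2=CC(=O)c3nc4n(c3C2=O)[C@H]2OC[C@@H](O)[C@H]2OC4)cc1` carries 4-ethoxyphenyl in place of 3-fluorophenyl on an amine nitrogen. Within the data shown here, the only measured exchange of one substituted phenyl group for another, a 1.3-fold higher number from compound 2 to compound 3 (0.10 log units; within the scatter), stayed within the scatter. The larger steps of an at least 3.1-fold lower number from compound 1 to compound 2 (0.49 log units; beyond the scatter) and an at least 2.4-fold lower number from compound 1 to compound 3 (0.39 log units; beyond the scatter) replaced azetidin-1-yl, a change compound 4 does not make. In this assay the expected result is therefore no shift beyond the scatter, in either direction: a 1.2-fold lower number from compound 3 to compound 4 (0.07 log units; within the scatter). For compound 4 the estimated value is 5500 nM, with an expected range from 2000 nM to 15000 nM.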

Compound 4, half-maximal inhibitory concentration: 3110 nM
Compound 4: middle estimate off by 1.8-fold (0.25 log units), on the high side; the measured number falls inside the stated range.
By their numbers in this assay, from the lowest: compounds 4, 2 and 3 (each within the scatter of the next, the first and the last beyond it). At a limit, above all of these: compound 1.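

In this assay, the change shows that exchanging one substituted phenyl group for another on this amine nitrogen can move the number beyond the scatter: a 2.1-fold lower number from compound 3 to compound 4 (0.32 log units; beyond the scatter) with 4-ethoxyphenyl in place of 3-fluorophenyl. Against the other fluorophenyl compound the shift stays within the scatter: a 1.6-fold lower number from compound 2 to compound 4 (0.22 log units; within the scatter) with 4-ethoxyphenyl in place of 2-fluorophenyl. Nothing measured here explains why the number moved. Still open, as far as these compounds go, is whether the ethoxy group itself or its ring position matters, which a 4-fluorophenyl compound could separate. A 4-methoxyphenyl group or a longer alkoxy chain could show whether chain length matters.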